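A few compounds are considered here, and "the series" means these few. Any claim that something is new, unique, unknown or untested is made for them only; others in the source may bear on it.

Within the data shown here, compound 2 `Cc1ccc2nc(C)n(NC(=O)/C(C#N)=C/c3ccc(Cl)cc3)c(=O)c2c1` gives 12000 nM in a functional assay on MCF7 cells (Homo sapiens) for cytotoxicity, read by MTT assay, with a stated time of 3 days (a higher number here means a weaker inhibitor, a lower number a stronger inhibitor), the highest of the two numbers measured so far. Its nearest neighbour is compound 1 `Cc1ccc(/C=C(\C#N)C(=O)Nn2c(C)nc3ccc(C)cc3c2=O)cc1`, which gives 10000 nM in this assay, and the step of a 1.2-fold higher number from compound 1 to compound 2 (0.08 log units; within the scatter) lies within the scatter. Compound 3 `Cc1ccc2nc(C)n(NC(=O)/C(C#N)=C/c3ccc([N+](=O)[O-])cc3)c(=O)c2c1` differs from compound 2 by nitro in place of chloro on an aromatic carbon, again on the ring carbon para to a large group. Among the measured compounds shown here, the only step that bears on a change at this place, a 1.2-fold higher number from compound 1 to compound 2 (0.08 log units; within the scatter), stayed within the scatter, so no shift beyond the scatter is expected in this assay. The expected step is no change at the digits printed from compound 2 to compound 3 (within the scatter). Compound 3 is therefore estimated at 12000 nM, within a range of 4000 nM to 40000 nM.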

Compound 3, half-maximal inhibitory concentration: 12000 nM
The estimate for compound 3 equals the measured number at the digits printed, and the stated range covers the measured number.
By their numbers in this assay, from the lowest: compounds 1, 2 and 3 (each within the scatter of the next).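

Nitro in place of chloro on the ring carbon para to a large group gives no change at the digits printed from compound 2 to compound 3 (within the scatter) and nitro in place of methyl gives a 1.2-fold higher number from compound 1 to compound 3 (0.08 log units; within the scatter) in the same place. Nitro, which brings two hydrogen-bond acceptors, therefore adds a third group at this carbon that this assay does not separate from the other two. No measurement here bears on the reason for this flat result. Still open, going by these compounds, is whether an amine or a carboxylic acid on this carbon would move the number beyond the scatter.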